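This account rests on a few compounds, and the source may have more. Where it says the series, first, only, none or still open, it means among the compounds named here.

Compound 2 `O=C(Nc1ccc(F)c(-c2nc3ncc(-c4ccccc4F)cc3[nH]2)c1)N1CCCC1` and compound 1 `O=C(Nc1ccc(F)c(-c2nc3ncc(-c4cccc(F)c4)cc3[nH]2)c1)N1CCCC1` share a core and differ only in where the fluoro sits on the outer phenyl ring. In an ADME assay on the whole organism (Mus musculus, strain Swiss Webster) for pharmacokinetics, read by LC-MS, at a dose of 50 mg/kg by the oral route (on this read-out higher numbers stand for higher exposure at the dose given and lower numbers for lower exposure), compound 1 gives 15000 ng.h/mL, and in this assay compound 2 gives 4870 ng.h/mL, the lower of the two numbers, with a 3.1-fold lower number from compound 1 to compound 2 (0.49 log units; beyond the scatter) separating them. Compound 3 `O=C(Nc1ccc(F)c(-c2nc3ncc(-c4cc(F)ccc4F)cc3[nH]2)c1)N1CCCC1` is the next member: fluoro in place of hydrogen on an aromatic carbon. Going by the values given here, the only measured step, the one from compound 1 to compound 2, moved a fluoro rather than adding one, so it bears on the change only loosely; nothing in the two measured values shows what a second fluoro on that ring does. Among the compounds with values here, with no step of the same kind to rest on, the expectation for this assay is a step of a 1.1-fold lower number from compound 2 to compound 3 (0.03 log units; within the scatter), treated as no change beyond the scatter. Compound 3 is therefore estimated at 4500 ng.h/mL, with a range from 1500 ng.h/mL to 13000 ng.h/mL.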

Compound 3, area under the concentration-time curve: 5620 ng.h/mL
Estimate against measurement, compound 3: 1.2-fold (0.10 log units) below, within the range that was stated.
By their numbers in this assay, from the lowest: compounds 2 and 3 (each within the scatter of the next); then compound 1.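

In this assay, the change from 2-fluorophenyl to 2,5-difluorophenyl, with the new fluoro meta to a large group and para to a fluoro group, gives a 1.2-fold higher number from compound 2 to compound 3 (0.06 log units; within the scatter), so this position takes a fluoro with no effect that can be told from the scatter. The same kind of change read from the other side gives a 2.7-fold lower number from compound 1 to compound 3 (0.43 log units; beyond the scatter), which places compound 3 with compound 2 and leaves compound 1 as the only one of the three set apart from the others beyond the scatter. No measurement at hand accounts for either step.

Open, from the compounds shown here alone, is whether this carbon tolerates anything larger than fluoro, such as a chloro, methoxy or amino group, to the same degree. Also open, going by these compounds, is whether a fluoro here, paired with a 3-fluorophenyl-like ring lacking the 2-fluoro, would behave as it does in compound 3.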